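A few compounds are considered here, and "the series" means these few. Any claim that something is new, unique, unknown or untested is made for them only; others in the source may bear on it.

Among the measured compounds shown here, in an assay (Rattus norvegicus) for inhibition of Fatty-acid amide hydrolase 1 (Homo sapiens) (on this read-out higher numbers stand for weaker inhibition and lower numbers for stronger inhibition), compound 3 `N#Cc1ccccc1-c1cnc(C(=O)CCCCCCc2ccccc2)o1` gives 130 nM, the second highest of the three numbers measured so far. Compound 1 `COC(=O)c1ccccc1-c1cnc(C(=O)CCCCCCc2ccccc2)o1` gives 60 nM, and compound 2 `O=C(CCCCCCc1ccccc1)c1ncc(-c2ccccc2C(=O)C(F)(F)F)o1` gives 5000 nM. The step of a 2.2-fold higher number from compound 1 to compound 3 (0.34 log units; beyond the scatter) was modest, whereas a 38-fold lower number from compound 2 to compound 3 (1.59 log units; beyond the scatter) and an 83-fold higher number from compound 1 to compound 2 (1.92 log units; beyond the scatter) were large, so the group carried on this phenyl ring clearly matters. Compound 4 `COc1ccc(-c2cnc(C(=O)CCCCCCc3ccccc3)o2)cc1` differs from compound 3 by 4-methoxyphenyl in place of 2-cyanophenyl on an aromatic carbon. For the measured compounds named here, no measured step exchanges the whole substituted phenyl for another, so the only guide is that compound 1 and compound 3 stay fairly close to each other. Compound 4 is therefore expected to show a step of about a 1.2-fold higher number from compound 3 to compound 4 (0.06 log units; within the scatter), within the scatter, with an estimate of 150 nM and a range from 40 nM to 600 nM.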

Compound 4, inhibition constant: 100 nM
Compound 4: the middle estimate sits 1.5-fold (0.18 log units) above what was measured; low and high end bracket the measured number.
By their numbers in this assay, from the lowest: compounds 1, 4 and 3 (each within the scatter of the next, the first and the last beyond it); then compound 2.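

In this assay, 4-methoxyphenyl in place of 2-cyanophenyl gives a 1.3-fold lower number from compound 3 to compound 4 (0.11 log units; within the scatter). The earlier steps shown here only exchanged one group on the phenyl ring for another, whereas this one replaces the whole substituted phenyl without the large change seen with compound 2. Nothing at hand gives a reason for this result.

On these data alone, because the group and its place on the phenyl ring change together, the effect of each alone stays open. Also open, as far as these compounds go, is how a plain phenyl, or a phenyl carrying an amine or a carboxylic acid, would compare.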